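Succinate and glutarate esters on a shared sulfonyl furoxan core

The source may hold more compounds than are shown below. What is called first, only, known or untested is meant among the compounds shown, and "the series" means these compounds.

Compound 1 `O=C(O)CCC(=O)OCCOc1no[n+]([O-])c1S(=O)(=O)c1ccccc1` gives 3800 nM in a functional assay on PC-3 cells (Homo sapiens) for antiproliferative activity, read by MTT assay, with a stated time of 72 h; a higher number here means a weaker inhibitor, a lower number a stronger inhibitor. Compound 2 `O=C(O)CCCC(=O)OCCOc1no[n+]([O-])c1S(=O)(=O)c1ccccc1` carries carboxymethyl in place of carboxy on a saturated chain carbon, two bonds along the chain from a carbonyl carbon and gives 5100 nM in this assay, a step of a 1.3-fold higher number from compound 1 to compound 2 (0.13 log units; within the scatter). Compound 3 `O=C(O)CCC(=O)OCCCOc1no[n+]([O-])c1S(=O)(=O)c1ccccc1` differs from compound 1 by (((2-carboxyethyl)carbonyl)oxy)methyl in place of ((2-carboxyethyl)carbonyl)oxy on a saturated chain carbon, two bonds along the chain from an oxygen on an aromatic ring. In this assay compound 3 reaches only a limit, > 10000 nM. The steps of an at least 2.6-fold higher number from compound 1 to compound 3 (0.42 log units; beyond the scatter) and an at least 1.9-fold higher number from compound 2 to compound 3 (0.29 log units; that floor lies within the scatter) both end at the limit of > 10000 nM in this assay, at which 1 of the 3 values shown sits.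

Compound 4 `O=C(O)CCCC(=O)OCCCOc1no[n+]([O-])c1S(=O)(=O)c1ccccc1` is not yet measured in this assay. It carries carboxymethyl in place of carboxy on a saturated chain carbon, two bonds along the chain from a carbonyl carbon, the same change as from compound 1 to compound 2, at the same place. The step from compound 3 to compound 4 is expected to be about a step that the limit leaves unreadable from compound 3 to compound 4, resting on the earlier step of a 1.3-fold higher number from compound 1 to compound 2 (0.13 log units; within the scatter). Compound 4 is therefore estimated at 15000 nM, likely between 7000 nM and 40000 nM, and most probably again only a limit.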

Compound 4, half-maximal inhibitory concentration: 3300 nM
Beside the measured number, compound 4's estimate is 4.5-fold (0.66 log units) above it; the whole stated range lies above it.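

In this assay, carboxymethyl in place of carboxy, on a saturated chain carbon, two bonds along the chain from a carbonyl carbon, gives an at least 3.0-fold lower number from compound 3 to compound 4 (0.48 log units; beyond the scatter), so the change does not carry over unchanged from the core of compound 1 to the core of compound 3: the same change on two cores in this assay, a 1.3-fold higher number (0.13 log units; within the scatter) from compound 1 to compound 2 and an at least 3.0-fold lower number (0.48 log units; beyond the scatter) from compound 3 to compound 4, at least 4.0-fold (0.60 log units) apart, beyond the scatter of two such steps

Compound 3 gives > 10000 nM, which is a limit of the assay and not a number. The result shows that this step depends on the core in these two pairs, but it does not show why, nor give the exact size of the step from the limit, nor predict the change on any other core.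

Still open, going by these compounds, is what a chain longer than 3-carboxypropyl would give on either core. The same holds for an amide in place of the ester.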